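The compounds below may be only part of what the source reports. "The series", "measured", "known", "first", "only" and "open" are said of these compounds alone.

Working notes on the series.

For the measured compounds named here, compound 1 `O=C(Nc1cccc(-n2cc(-c3ccncc3)c(-c3cc(O)cc(Cl)c3)n2)c1)Nc1ccc(Cl)c(Cl)c1` is the first member for which a number stands. In a functional assay on MDA-MB-468 cells (Homo sapiens) for inhibition, read by sulforhodamine B assay, with a stated time of 48 h, tested at 10 uM (on this read-out lower numbers stand for a stronger effect and higher numbers for a weaker effect at the one concentration tested), compound 1 gives -1.88%. Compound 2 `COc1cc(Cl)cc(-c2nn(-c3cccc(NC(=O)Nc4ccc(Cl)c(Cl)c4)c3)cc2-c2ccncc2)c1` differs from compound 1 in one place only, namely (methyl in place of hydrogen on an oxygen on an aromatic ring). In this assay compound 2 gives 0.72%, and the step of a number 2.6 percentage points higher from compound 1 to compound 2 (within the scatter) lies within the scatter, so no order between compound 1 and compound 2 is claimed.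

Compound 3 `O=C(Nc1cccc(-n2cc(-c3ccncc3)c(-c3cc(O)cc(Cl)c3)n2)c1)c1cc(C(F)(F)F)cc(C(F)(F)F)c1` carries the same 3-chloro-5-hydroxyphenyl group as compound 1 but on a different core; the difference between the two cores is not broken down here. In this assay compound 3 gives 31.2%, the highest of the three numbers, beyond the scatter from compound 2 and from compound 1 alike. On this read-out that stands for a weaker effect than either of the other two measured compounds.

Compound 4 `COc1cc(Cl)cc(-c2nn(-c3cccc(NC(=O)c4cc(C(F)(F)F)cc(C(F)(F)F)c4)c3)cc2-c2ccncc2)c1` has not been measured. It stands to compound 3 as compound 2 stands to compound 1, the change being (methyl in place of hydrogen on an oxygen on an aromatic ring), at a place that reads the same as in the earlier pair, so it is the same change. Going by the values given here, the one measured instance of this change, a number 2.6 percentage points higher from compound 1 to compound 2 (within the scatter), did not move the number beyond the scatter. On that basis the step is expected to be small again, with a number 1.8 percentage points higher from compound 3 to compound 4 (within the scatter) anticipated in this assay, resting on the behaviour of compound 1 and compound 2. Compound 4 is therefore estimated at 33% in this assay, with an expected range from 18% to 48%, since the core of compound 3 is expected to set the level and the methoxy to shift it little.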

Compound 4, a percentage reported as activity, at one concentration (the size of the read-out at that concentration, not a potency): 46.5%
Compound 4: middle estimate off by 13.5 percentage points, on the low side, and the stated range covers the measured number.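

In this assay, hydroxy to methoxy on the 3-chloro-5-hydroxyphenyl group of the core of compound 3 gives a number 15.3 percentage points higher from compound 3 to compound 4 (beyond the scatter), so on this core the change moves the number beyond the scatter, whereas on the core of compound 1 it did not. Even so, the two steps cannot be told apart once each is read with its own scatter: the same change on two cores in this assay, a number 2.6 percentage points higher (within the scatter) from compound 1 to compound 2 and a number 15.3 percentage points higher (beyond the scatter) from compound 3 to compound 4, 12.7 percentage points apart, within the scatter of two such steps. This shows that the change can be carried from one core to the other without a difference between the two steps that stands clear of the scatter, but it does not show that the step has the same size on both cores, and two pairs say nothing about how the change would behave on any further core.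

The compounds shown leave open what a longer chain on that oxygen, or an amine in place of the hydroxy, would do to the number on either core. Also open, from the compounds shown here alone, is whether the step on each core would hold at other concentrations, as the read-out stands for a single tested concentration and gives no potency.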